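The compounds below may be only part of what the source reports. "The series", "measured", "known", "first", "only" and "open" are said of these compounds alone.

Measured compounds:
compound 1 `COc1cc(-c2cc(/C=C/C(=O)c3ccc(N)cc3)[nH]n2)cc(OC)c1OC`, -85%
compound 2 `COc1ccc(-c2cc(/C=C/C(=O)c3ccc(N)cc3)[nH]n2)cc1OC`, -72%
compound 3 `COc1cc(C(=O)/C=C/c2cc(-c3cc(OC)c(OC)c(OC)c3)n[nH]2)cc(OC)c1OC`, -83%

In a functional assay on MDA-MB-435 cells (Homo sapiens) for cytotoxicity, read by sulforhodamine B assay, with a stated time of 48 h, tested at 100 uM (a lower number here means a stronger effect, a higher number a weaker effect of the compound at the concentration tested), compound 1 gives -85%. Compound 2 differs from compound 1 by hydrogen in place of methoxy on an aromatic carbon, and the step of a number 13 percentage points higher from compound 1 to compound 2 (beyond the scatter). Compound 3, which in this assay gives -83%, has a core whose difference from the core of compound 1 is not broken down here. Compound 4 `COc1ccc(-c2cc(/C=C/C(=O)c3cc(OC)c(OC)c(OC)c3)[nH]n2)cc1OC` is not yet measured; it differs from compound 3 by hydrogen in place of methoxy on an aromatic carbon, the same change as from compound 1 to compound 2. Resting on the step from compound 1 to compound 2, the expected step is a number 12 percentage points higher from compound 3 to compound 4 (beyond the scatter). Compound 4 is therefore estimated at -71% in this assay, with a range from -85% to -55%.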

Compound 4, a percentage reported as activity, at one concentration (the size of the read-out at that concentration, not a potency): -78%
Compound 4: middle estimate off by 7 percentage points, on the high side; measured number inside the range.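

On the core of compound 3 in this assay, hydrogen in place of methoxy gives a number 5 percentage points higher from compound 3 to compound 4 (within the scatter). Set beside the earlier step, the two steps cannot be told apart: the same change on two cores in this assay, a number 13 percentage points higher (beyond the scatter) from compound 1 to compound 2 and a number 5 percentage points higher (within the scatter) from compound 3 to compound 4, 8 percentage points apart, within the scatter of two such steps. Among these compounds, this shows that the change reads alike on these two cores, but with only two pairs it does not show a rule for other cores, and on the core of compound 3 the step alone does not establish an effect of the change.

As far as these compounds go, what a hydroxyl group, a fluorine atom or a longer chain such as ethoxy would give in place of that methoxy remains open. So does how these compounds compare at concentrations other than the one tested.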